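Bromo for fluoro: the next step in the series

This account rests on a few compounds, and the source may have more. Where it says the series, first, only, none or still open, it means among the compounds named here.

In a functional assay on MCF7 cells (Homo sapiens) for antiproliferative activity, read by MTT assay, with a stated time of 24 h (a lower number here means a stronger inhibitor, a higher number a weaker inhibitor), compound 3 (`Cc1ccc(-c2nn(-c3ccccc3)cc2-c2nc3ccccc3n2S(=O)(=O)c2ccc(F)cc2)cc1`) gives 5270 nM, the highest number of the three measured compounds, which makes it the weakest inhibitor among them. Compound 1 (`Cc1ccc(-c2nn(-c3ccccc3)cc2-c2nc3ccccc3n2S(=O)(=O)c2ccccc2)cc1`) gives 830 nM and compound 2 (`Cc1ccc(-c2nn(-c3ccccc3)cc2-c2nc3ccccc3n2S(=O)(=O)c2ccc(C)cc2)cc1`) gives 570 nM, and these two sit close together: a 1.5-fold lower number from compound 1 to compound 2 (0.16 log units; within the scatter).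

Compound 4 (`Cc1ccc(-c2nn(-c3ccccc3)cc2-c2nc3ccccc3n2S(=O)(=O)c2ccc(Br)cc2)cc1`) keeps the shared core and changes a single group: bromo in place of fluoro on an aromatic carbon.

The three measured compounds differ at this same place, so their steps are the best guide available. Two of them bear directly on the change, a 6.3-fold higher number from compound 1 to compound 3 (0.80 log units; beyond the scatter) and a 9.2-fold higher number from compound 2 to compound 3 (0.97 log units; beyond the scatter). Both show compound 3 standing apart from the other two, so replacing its fluoro may well bring the number down. Going by the values given here, no bromo compound has been measured, however, so the size of the step remains uncertain, and it could be smaller than those two.

In this assay the expected change is a 3.5-fold lower number from compound 3 to compound 4 (0.55 log units; beyond the scatter), a move towards a stronger inhibitor. For compound 4 the estimated value is 1500 nM, with an expected range from 450 nM to 5000 nM.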

Compound 4, half-maximal inhibitory concentration: 3160 nM
Compound 4: the middle estimate sits 2.1-fold (0.32 log units) below what was measured; low and high end bracket the measured number.
By their numbers in this assay, from the lowest: compounds 2 and 1 (each within the scatter of the next); then compounds 4 and 3 (each within the scatter of the next).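

In this assay, going by these compounds alone, bromo in place of fluoro gives a 1.7-fold lower number from compound 3 to compound 4 (0.22 log units; within the scatter), so compound 3 and compound 4 cannot be told apart, and changing this group on the ring does not by itself restore the lower numbers of the earlier compounds. Both steps from the other two compounds are beyond the scatter, with a 3.8-fold higher number from compound 1 to compound 4 (0.58 log units; beyond the scatter) and a 5.5-fold higher number from compound 2 to compound 4 (0.74 log units; beyond the scatter), so the higher number at this position is no longer seen with fluoro alone: among these four compounds, fluoro and bromo both go with higher numbers than hydrogen or methyl. Nothing available here explains why these groups separate in this way.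

Still open, going by these compounds, is whether chloro at the same place would join fluoro and bromo, or whether a larger alkyl group such as ethyl would stay with methyl and hydrogen. Methoxy and an amine at this position would test whether the split extends beyond these four groups, and the compounds shown cannot say whether it would hold with a different group elsewhere on the shared core.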